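The compounds below may be only part of what the source reports. "The series", "measured", "known", "first", "only" and "open" are said of these compounds alone.

Measured compounds in an assay on isolated protein for inhibition of N-acylethanolamine-hydrolyzing acid amidase (Homo sapiens), read by fluorescence, with a stated time of 90 min; a higher number here means a weaker inhibitor, a lower number a stronger inhibitor:
compound 1, `N#CN1CC(OCc2ccc(-c3ccccc3)cc2)C1`: 2.8 nM
compound 2, `COc1ccc(-c2ccc(COC3CN(C#N)C3)cc2)cc1`: 0.94 nM
compound 3, `N#CN1CC(OCc2ccc(Oc3ccccc3)cc2-c2ccccc2)C1`: 8.5 nM

Compound 2 differs from compound 1 by methoxy in place of hydrogen on an aromatic carbon. That change gave a 3.0-fold lower number from compound 1 to compound 2 (0.47 log units; beyond the scatter). Compound 3 carries a different core; the difference between the two cores is not broken down here. In this assay compound 3 gives 8.5 nM, the highest number of the three.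

Compound 4, `COc1ccccc1-c1cc(Oc2ccccc2)ccc1COC1CN(C#N)C1`, is not yet measured. It differs from compound 3 by methoxy in place of hydrogen on an aromatic carbon. This is the same kind of change as from compound 1 to compound 2, but not the same: there the methoxy entered para to a large group, here it enters ortho to a large group.

Going by the values given here, compound 4 is expected to give a lower number than compound 3, with a step estimated as a 1.7-fold lower number from compound 3 to compound 4 (0.23 log units; within the scatter), smaller than the earlier one, because a 3.0-fold lower number from compound 1 to compound 2 (0.47 log units; beyond the scatter) came from a methoxy para to a large group, whereas the place in compound 4 is ortho to a large group and no measured pair covers that. Compound 4 is estimated at 5 nM, between 2 nM and 14 nM.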

Compound 4, half-maximal inhibitory concentration: 23.7 nM
Beside the measured number, compound 4's estimate is 4.7-fold (0.68 log units) below it, and the stated range ends below it.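

In this assay, methoxy in place of hydrogen on an aromatic carbon, here ortho to a large group, gave a 2.8-fold higher number from compound 3 to compound 4 (0.45 log units; beyond the scatter), which makes compound 4 the weaker inhibitor of this pair. On these two pairs, the change does not carry from one core to the other with a fixed direction: the same change on two cores in this assay, a 3.0-fold lower number (0.47 log units; beyond the scatter) from compound 1 to compound 2 and a 2.8-fold higher number (0.45 log units; beyond the scatter) from compound 3 to compound 4, 8.3-fold (0.92 log units) apart, beyond the scatter of two such steps
The pairs differ in both the core and the place of the methoxy, and they do not show which of the two accounts for the gap, or whether any other change would transfer between these cores.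

Open, from the compounds shown here alone, is how methoxy behaves ortho to a large group on the core of compound 1, and at another place on the core of compound 3. Also open, going by these compounds, is whether the step from phenyl to 2-methoxyphenyl is particular to methoxy, or whether a methyl, a fluorine or an amine at that place would move the number the same way.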